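Aryl sulfonamides on a shared core: halogen exchange

The source may report more compounds than this note shows. Statements on the series, on what has been measured and on what is new or still open speak of the compounds shown alone.

Compound 1 `O=C1NCCN1c1ccc(S(=O)(=O)Nc2cccc(Br)c2)cc1` holds the lower of the two numbers given in a functional assay on HT-29 cells (Homo sapiens) for antiproliferative activity, read by sulforhodamine B assay, with a stated time of 48 h; on this read-out higher numbers stand for weaker inhibition and lower numbers for stronger inhibition: compound 1 gives 77 nM. Compound 3 `Cc1cccc(NS(=O)(=O)c2ccc(N3CCNC3=O)cc2)c1` gives 110 nM in this assay; the step of a 1.4-fold higher number from compound 1 to compound 3 (0.15 log units; within the scatter) lies within the scatter, so the two cannot be ordered against each other. Compound 2 `CCCCCCOc1ccc(NS(=O)(=O)c2ccc(N3CCNC3=O)cc2)cc1`, carrying the hexyloxy group, returns only a limit in this assay, > 1000 nM; this is the limit of > 1000 nM in this assay, at which 1 of the 3 values shown sits, not a number.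

Compound 4 `O=C1NCCN1c1ccc(S(=O)(=O)Nc2ccc(Cl)cc2)cc1` differs from compound 1 by 4-chlorophenyl in place of 3-bromophenyl on a sulfonamide nitrogen. Going by the values given here, the only measured step that touches the group on this sulfonamide nitrogen is a 1.4-fold higher number from compound 1 to compound 3 (0.15 log units; within the scatter), where methyl in place of bromo did not move the number beyond the scatter. Among the compounds with values here, no measured step exchanges bromine for chlorine, and none compares a 3-substituted with a 4-substituted phenyl on the nitrogen, so the data give no direction for the change. The small substituent-swap observed so far suggests a step no larger than the scatter, which is the expectation written as a 1.6-fold higher number from compound 1 to compound 4 (0.19 log units; within the scatter). Compound 4 is therefore estimated at 120 nM in this assay, with a range from 50 nM to 350 nM, while a limit such as that of compound 2 is not anticipated for a small aryl substituent.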

Compound 4, half-maximal inhibitory concentration: 220 nM
The estimate for compound 4 lay 1.8-fold (0.26 log units) below the measured number; the measured number falls inside the stated range.
By their numbers in this assay, from the lowest: compounds 1, 3 and 4 (each within the scatter of the next, the first and the last beyond it). At a limit, above all of these: compound 2.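

In this assay, the aryl group on the sulfonamide nitrogen can move the number beyond the scatter with no change in its count of heavy atoms: a 2.9-fold higher number from compound 1 to compound 4 (0.46 log units; beyond the scatter). The other new step at this position, a 2.0-fold higher number from compound 3 to compound 4 (0.30 log units; within the scatter), stays within the scatter, so the 3-methylphenyl group cannot be ordered against either halogen-bearing phenyl group, and only the two ends of this run separate. The exchange of hexyloxy for chloro reads an at least 4.5-fold lower number from compound 2 to compound 4 (0.65 log units; beyond the scatter), a bound and not a measured size, as one end of it is a limit: the limit of > 1000 nM in this assay, at which 1 of the 4 values shown sits.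

The change from 3-bromophenyl to 4-chlorophenyl alters the halogen and its place on the phenyl ring together, so the shown compounds cannot assign the step to either, and a 3-chlorophenyl or 4-bromophenyl group on the shared core would separate the two. Also open, on these data alone, is how an amine or a carboxylic acid on the phenyl group, or an alkoxy chain shorter than hexyloxy such as methoxy, would read in this assay.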